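The source may report more compounds than this note shows. Statements on the series, on what has been measured and on what is new or still open speak of the compounds shown alone.

Measured compounds:
compound 1 `Cc1cc(Nc2ccc(C(=O)/C=C/c3cccc(Br)n3)cc2)n2nc(SCc3ccc(Br)cc3)nc2n1`: 96.3%
compound 2 `Cc1cc(Nc2ccc(C(=O)/C=C/c3ccc(Br)cn3)cc2)n2nc(SCc3nc4ccccc4[nH]3)nc2n1`: 96.8%

Both compounds were tested in a functional assay on MGC-803 cells (Homo sapiens) for inhibition, read by sulforhodamine B assay, with a stated time of 72 h, tested at 10 uM; on this read-out higher numbers stand for more inhibition at the one concentration tested (going by the name of the read-out) and lower numbers for less inhibition. Compound 2 gives the higher of the two numbers, 96.8%, but compound 1 at 96.3% lies within the scatter of it, so the two cannot be told apart on this read-out. Compound 3 `Cc1cc(Nc2ccccc2)n2nc(SCc3nc4ccccc4[nH]3)nc2n1` has not been measured. It differs from compound 2 in one place: hydrogen in place of (2-(5-bromopyridin-2-yl)ethenyl)carbonyl on an aromatic carbon. Within the data shown here, no step between measured compounds is available to size this change, so the expectation rests on the structures alone. Removing a group of this size from compound 2 leaves a much smaller molecule, and a large downward step is expected in this assay, well beyond the scatter. Compound 3 is therefore estimated at 30%, within a range of 5% to 65%, an expected step of a number 66.8 percentage points lower from compound 2 to compound 3 (beyond the scatter).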

Compound 3, a percentage reported as inhibition, at one concentration (the size of the read-out at that concentration, not a potency): 22.4%
Beside the measured number, compound 3's estimate is 7.6 percentage points above it; the range from low to high includes it.
By their numbers in this assay, from the lowest: compound 3; then compounds 1 and 2 (each within the scatter of the next).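

In this assay, replacing (2-(5-bromopyridin-2-yl)ethenyl)carbonyl with hydrogen on this aromatic carbon gives a number 74.4 percentage points lower from compound 2 to compound 3 (beyond the scatter). Among these compounds, the earlier pair differed in more than one place, so this is the first single change that can be sized, and it shows that inhibition at the one concentration tested depends strongly on what sits at this position. The compounds shown offer no measurement that explains why this change matters so much.

Going by these compounds, the whole group goes in one step, so it remains open whether the pyridine ring, the bromine, the double bond or the carbonyl matters most. On these data alone, it is also open how much inhibition a smaller group on the same carbon, such as an acetyl or a carboxylic acid, would retain.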